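Fluoro for Methyl on Two Related Cores

The compounds below may be only part of what the source reports. "The series", "measured", "known", "first", "only" and "open" are said of these compounds alone.

Compound 1, `COc1cc2c(Oc3ccc(NC(=O)c4cc(-c5ccc(C)cc5)ccn4)cc3F)ccnc2cc1OCCCN1CCCC1`: 440 nM
Compound 2, `COc1cc2c(Oc3ccc(NC(=O)c4cc(-c5ccc(F)cc5)ccn4)cc3F)ccnc2cc1OCCCN1CCCC1`: 350 nM
Compound 3, `COc1cc2c(Oc3ccc(NC(=O)c4nccc(-c5ccc(C)cc5)n4)cc3F)ccnc2cc1OCCCN1CCCC1`: 240 nM

All three measured compounds were read in a functional assay on MKN-45 cells (Homo sapiens) for cytotoxicity, read by MTT assay, with a stated time of 72 h; on this read-out lower numbers stand for stronger inhibition and higher numbers for weaker inhibition. Compound 1 and compound 2 share one core and differ only in the change (fluoro in place of methyl on an aromatic carbon). That change made the step of a 1.3-fold lower number from compound 1 to compound 2 (0.10 log units; within the scatter), so the two values sit within the scatter of each other and no order between them can be claimed. Compound 3 carries a different core; the difference between the two cores is not broken down here. Its value in this assay stands nearest to compound 2 and furthest from compound 1, but both gaps lie within the scatter.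

Compound 4, `COc1cc2c(Oc3ccc(NC(=O)c4nccc(-c5ccc(F)cc5)n4)cc3F)ccnc2cc1OCCCN1CCCC1`, has not yet been measured. It differs from compound 3 by fluoro in place of methyl on an aromatic carbon, the same change that separates compound 2 from compound 1, made at the same place. Among the compounds with values here, since the step from compound 1 to compound 2 was small and within the scatter, the expectation for compound 4 is a step of similar size, estimated as a 1.3-fold lower number from compound 3 to compound 4 (0.10 log units; within the scatter), resting on a 1.3-fold lower number from compound 1 to compound 2 (0.10 log units; within the scatter) as the only precedent. Accordingly compound 4 is expected to give about 190 nM in this assay, estimated to fall between 90 nM and 400 nM.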

Compound 4, half-maximal inhibitory concentration: 490 nM
For compound 4 the middle estimate is 2.6-fold (0.41 log units) below the measured one, outside the stated range (above it).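

In this assay, putting fluoro in place of methyl on the core of compound 3, which turns 4-methylphenyl into 4-fluorophenyl, gave a 2.0-fold higher number from compound 3 to compound 4 (0.31 log units; beyond the scatter), a modest step that only just clears the usual spread of repeated measurements. Set beside the same change on the other core, this step does not stand apart from the earlier one: the same change on two cores in this assay, a 1.3-fold lower number (0.10 log units; within the scatter) from compound 1 to compound 2 and a 2.0-fold higher number (0.31 log units; beyond the scatter) from compound 3 to compound 4, 2.6-fold (0.41 log units) apart, within the scatter of two such steps. The two pairs therefore give no firm ground for saying that the core alters what this change does, yet two pairs are too few to show that the change carries from one core to the other with a fixed size, so the question stays unsettled rather than answered either way.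

The compounds shown carry only 4-methylphenyl and 4-fluorophenyl, so it remains open whether a chloro, methoxy or trifluoromethyl group in the same place would give steps on the two cores that could clearly be told apart. Also open, as far as these compounds go, is whether an amine or a carboxylic acid at that place would follow the same course on both cores, or whether the two cores would then part.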